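A few compounds are considered here, and "the series" means these few. Any claim that something is new, unique, unknown or untested is made for them only; others in the source may bear on it.

Compound 1 `COC(=O)Nc1nc2ccc(NC(=O)c3c(Cl)cccc3Cl)cc2s1`: 0.0095 ug/mL
Compound 2 `CC(C)OC(=O)Nc1nc2ccc(NC(=O)c3c(Cl)cccc3Cl)cc2s1`: 0.0026 ug/mL
Compound 3 `O=C(Nc1nc2ccc(NC(=O)c3c(Cl)cccc3Cl)cc2s1)OCc1ccccc1`: 0.018 ug/mL

In a functional assay on WI-38 VA13 cells (Homo sapiens) for cytotoxicity (a lower number here means that less compound is needed, a higher number that more compound is needed for the effect), compound 3 stands at the highest of the three numbers. The step of a 1.9-fold higher number from compound 1 to compound 3 (0.28 log units; within the scatter) lies within the scatter, whereas the step of a 6.9-fold higher number from compound 2 to compound 3 (0.84 log units; beyond the scatter) lies beyond it. Compound 4 `COc1ccccc1Nc1nc2ccc(NC(=O)c3c(Cl)cccc3Cl)cc2s1` differs from compound 3 by 2-methoxyphenyl in place of benzyloxycarbonyl on a nitrogen on an aromatic ring. Among the measured compounds shown here, no measured step removes the whole benzyloxycarbonyl group; the known steps of a 3.7-fold lower number from compound 1 to compound 2 (0.56 log units; beyond the scatter) and a 6.9-fold higher number from compound 2 to compound 3 (0.84 log units; beyond the scatter) only exchange one piece of it, and the three measured values are separated by steps no larger than these. The step of a 1.7-fold higher number from compound 3 to compound 4 (0.22 log units; within the scatter) is therefore expected to be modest at most, with its direction uncertain, and compound 4 is estimated at 0.03 ug/mL, within 0.005 ug/mL to 0.2 ug/mL.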

Compound 4, half-maximal effective concentration: > 7.2 ug/mL
Compound 4: no number, only a limit; the forecaster's own chance of this, stated with the estimate: 5%; at least 240-fold (2.38 log units) between middle value and limit.
By their numbers in this assay, from the lowest: compound 2; then compounds 1 and 3 (each within the scatter of the next). At a limit, above all of these: compound 4.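

In this assay the value of compound 4 is a limit of the assay and not a number: the limit of > 7.2 ug/mL in this assay, at which 1 of the 4 values shown sits. Exchanges among methoxycarbonyl, isopropoxycarbonyl and benzyloxycarbonyl on this nitrogen on an aromatic ring had given modest steps at most. With 2-methoxyphenyl in their place the steps are large: an at least 400-fold higher number from compound 3 to compound 4 (2.60 log units; beyond the scatter), an at least 2700-fold higher number from compound 2 to compound 4 (3.44 log units; beyond the scatter) and an at least 750-fold higher number from compound 1 to compound 4 (2.87 log units; beyond the scatter).

The compounds shown do not separate the loss of the carbonyl from the entry of the 2-methoxyphenyl ring. As far as these compounds go, how a free amine or an acetyl group on this nitrogen would stand remains open.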